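This account rests on a few compounds, and the source may have more. Where it says the series, first, only, none or still open, it means among the compounds named here.

In a functional assay on MCF7 cells (Homo sapiens) for antiproliferative activity, read by MTT assay, with a stated time of 24 h (on this read-out higher numbers stand for weaker inhibition and lower numbers for stronger inhibition), compound 1 (`CCN(CC)CCNC(=O)C1CC(C(CC)(CC)c2ccc(C#CC(C)(C)O)c(C)c2)=CN1CC`) gives 3170 nM. Compound 2 (`C#Cc1ccc(C(CC)(CC)C2=CN(CC)C(C(=O)NCCN(CC)CC)C2)cc1C`) gives only a limit, > 50000 nM, and so has no exact place on the numbers. Among the measured compounds shown here, the one measured step that bears on what follows is an at least 15-fold higher number from compound 1 to compound 2 (1.19 log units; beyond the scatter), which is large and came with hydrogen in place of 1-hydroxy-1-methylethyl on a triple-bonded carbon. Compound 3 (`CCN(CC)CCNC(=O)C1CC(C(CC)(CC)c2ccc(/C=C/C(O)(CC)CC)c(C)c2)=CN1CC`) differs from compound 2 on an aromatic carbon, ortho to a methyl group: a group of 8 heavy atoms (7 carbon, 1 oxygen; no ring) in place of a group of 2 heavy atoms (2 carbon; no ring), on an aromatic carbon. The entering group contains oxygen, as the group lost from compound 1 did. Compound 3 is therefore expected to move back towards compound 1 at 3170 nM, with a large change to lower numbers in this assay. The expected step is an at least 16-fold lower number from compound 2 to compound 3 (1.22 log units; beyond the scatter). The estimate for compound 3 is 3000 nM, with an expected range of 700 nM to 15000 nM.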

Compound 3, half-maximal inhibitory concentration: 690 nM
Compound 3: middle estimate off by 4.3-fold (0.64 log units), on the high side, outside the stated range (below it).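

Among the compounds shown here, on this aromatic carbon, ortho to a methyl group and para to a large group, the earlier compounds showed only a loss, whereas the group of 8 heavy atoms in place of ethynyl gives an at least 72-fold lower number from compound 2 to compound 3 (1.86 log units; beyond the scatter). The value of compound 2 in this comparison is a limit of the assay and not a number: the limit of > 50000 nM in this assay, at which 1 of the 3 values shown sits. The oxygen-bearing group of compound 1 is also not the best seen at this position, as its replacement by the larger group gives a modest gain, a 4.6-fold lower number from compound 1 to compound 3 (0.66 log units; beyond the scatter).

Compound 3 differs from compound 1 in both the double bond and the larger chain, and the shown compounds do not separate these two changes. Also open, from the compounds shown here alone, is whether an amine or a carboxylic acid in place of the oxygen-bearing end of the chain would keep this activity.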